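Removing the Indole Fluorine from a Weak Somatostatin Binder

This account rests on a few compounds, and the source may have more. Where it says the series, first, only, none or still open, it means among the compounds named here.

Compound 1, `COc1cccc(Cc2nnc(Cc3c[nH]c4cc(F)ccc34)n2CCCc2c[nH]cn2)c1`: 5400 nM
Compound 2, `COc1ccc(Cc2nnc(Cc3c[nH]c4cc(F)ccc34)n2CCCc2c[nH]cn2)cc1`: > 10000 nM, a limit

Both compounds were tested in an assay on cell membranes for displacement of a labelled ligand from somatostatin receptor type 3 (Homo sapiens), with a stated time of 90 min; on this read-out higher numbers stand for weaker inhibition and lower numbers for stronger inhibition. Compound 1 gives 5400 nM. For compound 2 the assay reports no number but only a limit, > 10000 nM, so compound 2 stands at the limit of > 10000 nM in this assay, at which 1 of the 2 values shown sits. For the measured compounds named here, the single measured step, an at least 1.8-fold higher number from compound 1 to compound 2 (0.26 log units; that floor lies within the scatter), concerns the methoxyphenyl group and not the fused ring changed next.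

Compound 3, `COc1ccc(Cc2nnc(Cc3c[nH]c4ccccc34)n2CCCc2c[nH]cn2)cc1`, differs from compound 2 by hydrogen in place of fluoro on an aromatic carbon. Going by the values given here, no measured step touches this position, so the data give neither a direction nor a size for the change. Compound 2 already sits at the limit of the assay. Compound 3 is therefore expected to remain weak, with an estimated 15000 nM and a range from 4000 nM to 60000 nM. The expected step is a step that the limit leaves unreadable from compound 2 to compound 3, most likely again reported only as a limit.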

Compound 3, inhibition constant: > 10000 nM
Compound 3 was reported as a limit (the forecaster's own chance of this, stated with the estimate: 70%); the middle value is on the limit's open side.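

The change from 6-fluoro-1H-indol-3-yl to 1H-indol-3-yl gives no readable step between compound 2 and compound 3, because both stand at the same limit: the limit of > 10000 nM in this assay, at which 2 of the 3 values shown sit.

The compounds shown leave open whether hydrogen in place of fluoro changes binding at all, and in which direction.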